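A few compounds are considered here, and "the series" means these few. Any claim that something is new, unique, unknown or untested is made for them only; others in the source may bear on it.

Measured so far in a functional assay on NIH3T3 cells (Mus musculus); a higher number here means that more compound is needed for the effect, a lower number that less compound is needed:
- compound 1, `Cn1cncc1C(OCc1ccc(C#N)cc1-c1ccccc1)c1ccc(C#N)cc1`: 140 nM
- compound 2, `CCC/C=C/C=C/c1cc(C#N)ccc1COC(c1ccc(C#N)cc1)c1cncn1C`: 16.7 nM

Among the measured compounds shown here, compound 2 stands at the lower of the two numbers in this assay; its only neighbour is compound 1, and the single measured step, an 8.4-fold lower number from compound 1 to compound 2 (0.92 log units; beyond the scatter), separates them. Compound 3, `Cn1cncc1C(OCc1ccc(C#N)cc1CCC(C)(C)C)c1ccc(C#N)cc1`, is not yet measured. The change from compound 2 is 3,3-dimethylbutyl in place of hepta-1,3-dien-1-yl on an aromatic carbon. For the measured compounds named here, only the step from compound 1 to compound 2 bears on this: it put in the same hepta-1,3-dien-1-yl that now leaves, and it lowered the number. Going by the values given here, no measured pair shows a 3,3-dimethylbutyl on this carbon, so the direction of the new step is open; a drift back toward the number of compound 1 is as plausible as no change beyond the scatter. Compound 3 is therefore expected to give about 40 nM in this assay, with a range of 12 nM to 130 nM. That estimate means a step of a 2.4-fold higher number from compound 2 to compound 3 (0.38 log units; beyond the scatter), which is expected to be modest.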

Compound 3, half-maximal effective concentration: 0.54 nM
Compound 3: the middle estimate sits 74-fold (1.87 log units) above what was measured; the measured number lies below the stated range.
By their numbers in this assay, from the lowest: compound 3; then compound 2; then compound 1.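

In this assay, the choice of group on this aromatic carbon, ortho to a large group and meta to a cyano group, has a much larger effect than the first step indicated: a 31-fold lower number from compound 2 to compound 3 (1.49 log units; beyond the scatter), and overall a 260-fold lower number from compound 1 to compound 3 (2.41 log units; beyond the scatter), against an 8.4-fold lower number from compound 1 to compound 2 (0.92 log units; beyond the scatter). Both open-chain groups give lower numbers than phenyl, and 3,3-dimethylbutyl, with no double bonds outside aromatic rings and one heavy atom fewer than hepta-1,3-dien-1-yl, gives the lowest of the three. No measurement at hand explains the size of these steps.

The compounds shown do not separate the effect of the branched chain end from that of losing the two double bonds, and an unbranched hexyl chain would bear on that question. As far as these compounds go, how far this position accepts a group other than a hydrocarbon, such as a chain ending in an amine or a carboxylic acid, also remains open.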